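A few compounds are considered here, and "the series" means these few. Any claim that something is new, unique, unknown or untested is made for them only; others in the source may bear on it.

In a functional assay on MGC-803 cells (Homo sapiens) for antiproliferative activity, read by MTT assay, with a stated time of 72 h (a higher number here means a weaker inhibitor, a lower number a stronger inhibitor), compound 2 `CCCSc1nc(N/N=C(\C)c2ccccc2O)c2nnn(Cc3ccccc3)c2n1` gives 2310 nM. Compound 1 `CCCSc1nc(N/N=C(\C)c2ccccc2O)c2nnn(Cc3ccc(F)cc3)c2n1` gives 11000 nM there; it carries the change (fluoro in place of hydrogen on an aromatic carbon), and that change makes a 4.8-fold higher number from compound 2 to compound 1 (0.68 log units; beyond the scatter).

Compound 3 `CCCSc1nc(N/N=C/c2ccccc2)c2nnn(Cc3ccccc3)c2n1` gives > 64000 nM in this assay, and that value is a limit of the assay rather than a number. Compound 3 stands at the limit of > 64000 nM in this assay, at which 1 of the 3 values shown sits. Compound 3 differs from compound 2 by a group of 8 heavy atoms (7 carbon, 1 nitrogen; one six-membered aromatic ring of carbon only) in place of a group of 10 heavy atoms (8 carbon, 1 nitrogen, 1 oxygen; one six-membered aromatic ring of carbon only), on a nitrogen on an aromatic ring, and that difference brings an at least 27-fold higher number from compound 2 to compound 3 (1.44 log units; beyond the scatter).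

Compound 4 `CCCSc1nc(N/N=C/c2ccccc2F)c2nnn(Cc3ccccc3)c2n1` has not yet been measured in this assay. Compound 4 differs from compound 3 by fluoro in place of hydrogen on an aromatic carbon. Within the data shown here, this is the same kind of change as the one from compound 2 to compound 1, a fluoro in place of hydrogen on an aromatic carbon, but it is not the same: in compound 1 the fluoro sits para to a large group, whereas in compound 4 it sits ortho to a large group. The two cores also differ, by the change a group of 8 heavy atoms (7 carbon, 1 nitrogen; one six-membered aromatic ring of carbon only) in place of a group of 10 heavy atoms (8 carbon, 1 nitrogen, 1 oxygen; one six-membered aromatic ring of carbon only), on a nitrogen on an aromatic ring described above.

Starting from a compound that already sits at the limit, the expectation for compound 4 is that the fluoro gives a step that the limit leaves unreadable from compound 3 to compound 4, by analogy with the step of a 4.8-fold higher number from compound 2 to compound 1 (0.68 log units; beyond the scatter), which weakened the inhibitor rather than strengthening it. Compound 4 is therefore estimated at 120000 nM, with a likely range from 40000 nM to 400000 nM, and it is most likely that this assay will again report only a limit for compound 4.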

Compound 4, half-maximal inhibitory concentration: > 64000 nM
Compound 4 was reported as a limit (the forecaster's own chance of this, stated with the estimate: 75%); the middle value does not contradict the limit.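

In this assay compound 4 gives > 64000 nM, which is a limit of the assay and not a number. The step between compound 3 and compound 4 cannot be read, because both values are limits, so the size of the phenyl to 2-fluorophenyl change on this core stays hidden: the limit of > 64000 nM in this assay, at which 2 of the 4 values shown sit.

What can be read is an at least 27-fold higher number from compound 2 to compound 4 (1.44 log units; beyond the scatter), alongside the earlier fluoro step, a 4.8-fold higher number from compound 2 to compound 1 (0.68 log units; beyond the scatter); this shows that compound 4 remains far weaker than compound 2, but it does not show whether fluoro in place of hydrogen has the same effect on both cores, since the change neither repeats nor fails to repeat in any readable way.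

A fair test would need the fluoro on a compound whose value is a real number, as with compound 2, so that a step could be measured on each side. From the compounds shown here alone, it also remains open whether an amine or a carboxylic acid on the 2-fluorophenyl ring, or a longer chain in place of the propyl chain on sulfur, would bring the value of this weak pair back within the range of the assay.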